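This account rests on a few compounds, and the source may have more. Where it says the series, first, only, none or still open, it means among the compounds named here.

Compound 1 `Nc1nc(N2CCCC2)sc1C(=O)/C=C/c1ccc(Cl)cc1` and compound 2 `Nc1nc(N2CCCC2)sc1C(=O)/C=C/c1ccc(Br)cc1` share one core and differ only by bromo in place of chloro on an aromatic carbon. In a functional assay on HepG2 cells (Homo sapiens) for antiproliferative activity, read by MTT assay, with a stated time of 48 h (on this read-out higher numbers stand for weaker inhibition and lower numbers for stronger inhibition), compound 1 gives 27 ug/mL, while compound 2 gives 30 ug/mL, so that a 1.1-fold higher number from compound 1 to compound 2 (0.05 log units; within the scatter). Compound 3 `Nc1nc(N2CCCCC2)sc1C(=O)/C=C/c1ccc(Cl)cc1` differs from compound 1 by piperidin-1-yl in place of pyrrolidin-1-yl on an aromatic carbon; in this assay compound 3 gives 12 ug/mL, and a 2.3-fold lower number from compound 1 to compound 3 (0.35 log units; beyond the scatter). Compound 4 `Nc1nc(N2CCCCC2)sc1C(=O)/C=C/c1ccc(Br)cc1` differs from compound 3 by bromo in place of chloro on an aromatic carbon, the same change at the same place as between compound 1 and compound 2. For compound 4 the step expected in this assay is a 1.1-fold higher number from compound 3 to compound 4 (0.03 log units; within the scatter), beside the earlier 1.1-fold higher number from compound 1 to compound 2 (0.05 log units; within the scatter), and this expectation rests on that single measured pair alone. Compound 4 is therefore estimated at 13 ug/mL, with a likely range from 7 ug/mL to 25 ug/mL.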

Compound 4, half-maximal inhibitory concentration: 17.4 ug/mL
For compound 4 the middle estimate is 1.3-fold (0.13 log units) below the measured one, and the stated range covers the measured number.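

In this assay, bromo in place of chloro gives a 1.5-fold higher number from compound 3 to compound 4 (0.16 log units; within the scatter), and this step carries from one core to the other without a discernible difference: the same change on two cores in this assay, a 1.1-fold higher number (0.05 log units; within the scatter) from compound 1 to compound 2 and a 1.5-fold higher number (0.16 log units; within the scatter) from compound 3 to compound 4, 1.3-fold (0.12 log units) apart, within the scatter of two such steps

Piperidin-1-yl in place of pyrrolidin-1-yl gives a 1.7-fold lower number from compound 2 to compound 4 (0.24 log units; within the scatter), and it also agrees with its earlier counterpart: the same change on two cores in this assay, a 2.3-fold lower number (0.35 log units; beyond the scatter) from compound 1 to compound 3 and a 1.7-fold lower number (0.24 log units; within the scatter) from compound 2 to compound 4, 1.3-fold (0.12 log units) apart, within the scatter of two such steps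

This shows that both changes transfer consistently across these four compounds, but it rests on one pair per change, does not establish any order between the chloro and bromo compounds, and does not show that either step would hold on another core.

The compounds shown leave open whether morpholin-4-yl in place of the piperidin-1-yl group, or methoxy in place of the halogen, would follow the same pattern.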